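The source may report more compounds than this note shows. Statements on the series, on what has been measured and on what is new or still open speak of the compounds shown alone.

Working notes on the series. Compound 1 `CCCCc1ccc(CNC(=O)OC(C)(C)C)c(=O)n1Cc1ccc(-c2ccccc2-c2nn[nH]n2)cc1`, compound 2 `CCCCc1ccc(CN(C)S(C)(=O)=O)c(=O)n1Cc1ccc(-c2ccccc2-c2nn[nH]n2)cc1` and compound 3 `CCCCc1ccc(CN(Cc2ccccc2)S(=O)(=O)c2ccc(C)cc2)c(=O)n1Cc1ccc(-c2ccccc2-c2nn[nH]n2)cc1` share one core and differ only in the group carried on the saturated chain carbon bound to the aromatic carbon. In a functional assay (aorta) for antagonist activity, with Oryctolagus cuniculus as the target (a lower number here means a stronger inhibitor, a higher number a weaker inhibitor), compound 1 gives 10 nM, compound 2 gives 0.2 nM and compound 3 gives 60 nM. Compound 2 stands lowest of the three: the step of a 50-fold lower number from compound 1 to compound 2 (1.70 log units; beyond the scatter) is large and beyond the scatter, and compound 3 sits further away still. Compound 4 `CCCCc1ccc(CN(CC)S(C)(=O)=O)c(=O)n1Cc1ccc(-c2ccccc2-c2nn[nH]n2)cc1` has not been measured. It differs from compound 2 in one place, (methyl in place of hydrogen on a saturated chain carbon bound to a sulfonamide nitrogen). No measured step matches this change: the one step shown, a 50-fold lower number from compound 1 to compound 2 (1.70 log units; beyond the scatter), exchanges the whole group on the nitrogen, and compound 3 differs from compound 2 in two places at once, so the value of compound 3, 60 nM, cannot be split into parts. With a small change and no comparable step shown, a step of a 2.0-fold higher number from compound 2 to compound 4 (0.30 log units; within the scatter) is expected, not clearly beyond the scatter. Compound 4 is therefore expected to give 0.4 nM in this assay, estimated between 0.1 nM and 1.5 nM.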

Compound 4, half-maximal inhibitory concentration: 2 nM
Compound 4: the middle estimate sits 5.0-fold (0.70 log units) below what was measured; the measured number lies above the stated range.
By their numbers in this assay, from the lowest: compound 2; then compound 4; then compound 1; then compound 3.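

In this assay this position proves sensitive to a very small change: methyl to ethyl on the sulfonamide nitrogen, one added carbon, gives a 10-fold higher number from compound 2 to compound 4 (1.00 log units; beyond the scatter). The ethyl(methylsulfonyl)amino group still keeps an advantage over (tert-butoxycarbonyl)amino, with a 5.0-fold lower number from compound 1 to compound 4 (0.70 log units; beyond the scatter), so the gain from that exchange is reduced by the added methyl but not lost. No measurement at hand accounts for the size of this step.

Going by these compounds, with only methyl and ethyl compared on this nitrogen, it remains open whether a propyl or longer chain there would raise the number further, and how a plain hydrogen on the nitrogen would compare. Also open, on these data alone, is how an ethylsulfonyl group in place of the methylsulfonyl group would read.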